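Notes on compound 2 and its isomer compound 3

The source may hold more compounds than are shown below. What is called first, only, known or untested is meant among the compounds shown, and "the series" means these compounds.

Measured so far in a functional assay (aorta) with Rattus norvegicus as the target, in the presence of a further agent that is not named here; a lower number here means that less compound is needed, a higher number that more compound is needed for the effect:
- compound 1 `COC(=O)C1=C(C)N=C(C)/C(=C(/O)OC)C1c1ccccc1OCc1nonc1C`: 41 nM
- compound 2 `COC(=O)C1=C(C)N=C(C)/C(=C(/O)OC)C1c1ccccc1OCc1c(C)no[n+]1[O-]`: 78 nM

Among the measured compounds shown here, compound 2 gives 78 nM and stands within the scatter of compound 1, the only other compound measured. The next compound is compound 3 `COC(=O)C1=C(C)N=C(C)/C(=C(/O)OC)C1c1ccccc1OCc1no[n+]([O-])c1C`, which keeps the shared core and changes only the ring group: a group of 7 heavy atoms (3 carbon, 2 nitrogen, 2 oxygen; one five-membered aromatic ring with 3 hetero atoms) in place of a group of 7 heavy atoms (3 carbon, 2 nitrogen, 2 oxygen; one five-membered aromatic ring with 3 hetero atoms), on a saturated chain carbon bound to an oxygen on an aromatic ring. The two have the same atoms, joined differently. For the measured compounds named here, no measured step covers this exact exchange. Going by the values given here, one measured step bears on it, as it also replaces one ring group with another at the same place: a 1.9-fold higher number from compound 1 to compound 2 (0.28 log units; within the scatter). On these data alone, with that single step as the guide, no change beyond the scatter is expected in this assay, and the direction remains open. The expected step is a 1.2-fold lower number from compound 2 to compound 3 (0.08 log units; within the scatter). Compound 3 is estimated at 65 nM, with an expected range of 22 nM to 190 nM.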

Compound 3, half-maximal effective concentration: 43 nM
Compound 3: the middle estimate sits 1.5-fold (0.18 log units) above what was measured, within the range that was stated.
By their numbers in this assay, from the lowest: compounds 1, 3 and 2 (each within the scatter of the next).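

The isomer exchange on the saturated chain carbon bound to an oxygen on an aromatic ring, which keeps the same atoms but joins them differently, gives a 1.8-fold lower number from compound 2 to compound 3 (0.26 log units; within the scatter) in this assay. Rejoining the atoms of this five-membered aromatic ring with 3 hetero atoms therefore leaves the number within the scatter in this pair, and the step from the smaller ring group to this isomer gives a 1.0-fold higher number from compound 1 to compound 3 (0.02 log units; within the scatter) as well, so all three ring groups shown at this place lie within the scatter of one another, with no exception among the listed compounds. No supporting data accompany these numbers, so nothing shown accounts for the closeness of the three values or gives any of the small differences a meaning.

On these data alone, it remains open whether this place tolerates groups of another kind, such as an amine, a carboxylic acid or a plain longer chain in place of the five-membered ring, or whether those would give a step beyond the scatter. The compounds shown also leave open whether the three ring groups stay this close in any read-out other than this assay, or without the further agent present.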